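The compounds below may be only part of what the source reports. "The series", "measured", "known", "first", "only" and "open" are said of these compounds alone.

Compound 1 `COc1ccc(-c2cc(-c3ccc(S(N)(=O)=O)cc3)cnc2N)cn1` was tested in an in vitro ADME assay on microsomes from liver (Homo sapiens) for metabolic stability; on this read-out higher numbers stand for fast clearance and lower numbers for slow clearance. In this assay compound 1 gives < 7 mL.min-1.g-1, which is a limit of the assay rather than a number. A second compound, compound 2 `COc1ccc(-c2cc(-c3ccc(S(C)(=O)=O)cc3C(F)(F)F)cnc2N)cn1`, shares the same core. In this assay compound 2 gives < 7 mL.min-1.g-1, again a limit of the assay. The two measured values thus sit at the same edge: the limit of < 7 mL.min-1.g-1 in this assay, at which 2 of the 2 values shown sit. Among the measured compounds shown here, no step between two measured compounds is available, so compound 1 cannot be ranked against any neighbour and simply stands at the limit.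

Compound 3 `COc1ccc(-c2cc(-c3ccc(-n4cncn4)cc3)cnc2N)cn1` has not yet been measured in this assay. It differs from compound 1 in one place: 1H-1,2,4-triazol-1-yl in place of sulfamoyl on an aromatic carbon. For the measured compounds named here, with no measured step to gauge this change against, the expected step of an at least 1.1-fold higher number from compound 1 to compound 3 (0.05 log units; that floor lies within the scatter) is small, leaning toward faster clearance but not beyond the usual scatter. Compound 3 is expected to give about 8 mL.min-1.g-1, between 3 mL.min-1.g-1 and 25 mL.min-1.g-1, in this assay.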

Compound 3, intrinsic clearance in microsomes: 8 mL.min-1.g-1
Compound 3: the middle estimate sits on the measured number at the digits printed, and the stated range covers the measured number.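

Replacing sulfamoyl with 1H-1,2,4-triazol-1-yl on this aromatic carbon gives an at least 1.1-fold higher number from compound 1 to compound 3 (0.05 log units; that floor lies within the scatter) in this assay. This floor is all that can be read, as compound 1 has a limit and not a number, so the real step could be larger. The change also brings the only exact number in this small set, while the other compounds stay at the edge of the assay: the limit of < 7 mL.min-1.g-1 in this assay, at which 2 of the 3 values shown sit.

From the compounds shown here alone, the actual size of the step from sulfamoyl to 1H-1,2,4-triazol-1-yl therefore remains open. Also open, going by these compounds, is how a carboxylic acid or a primary amine on the same aromatic carbon would compare with these two groups in this assay.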